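The source may hold more compounds than are shown below. What is called first, only, known or untested is meant among the compounds shown, and "the series" means these compounds.

Measured so far:
compound 1 `CC(C)c1n[nH]c2c(NCc3ccc(-c4ccccn4)cc3)nc(SCCNC(=N)N)nc12`: 390 nM
compound 2 `CC(C)c1n[nH]c2c(NCc3ccc(-c4ccccn4)cc3)nc(SCCCN(C)C)nc12`: 105 nM
compound 3 `CC(C)c1n[nH]c2c(NCc3ccc(-c4ccccn4)cc3)nc(S)nc12`: 2760 nM

In a functional assay on HT cells (Homo sapiens) for antiproliferative activity, read by fluorescence, with a stated time of 72 h (on this read-out higher numbers stand for weaker inhibition of growth and lower numbers for stronger inhibition of growth), compound 2 stands lowest of the three. Its nearest neighbour is compound 1: a 3.7-fold lower number from compound 1 to compound 2 (0.57 log units; beyond the scatter). Its furthest is compound 3: a 26-fold higher number from compound 2 to compound 3 (1.42 log units; beyond the scatter). The remaining step is a 7.1-fold higher number from compound 1 to compound 3 (0.85 log units; beyond the scatter).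

Compound 4 `CC(C)c1n[nH]c2c(NCc3ccc(-c4ccccn4)cc3)nc(SCCCN)nc12` has not yet been measured. It differs from compound 2 by amino in place of dimethylamino on a saturated chain carbon, three bonds along the chain from a sulfur. Of the measured steps, the exchange of the chain's end group, a 3.7-fold lower number from compound 1 to compound 2 (0.57 log units; beyond the scatter), was modest, while loss of the entire chain, a 26-fold higher number from compound 2 to compound 3 (1.42 log units; beyond the scatter), was large. Compound 4 keeps the chain and only alters its end, so a small step toward a higher number is expected, possibly within the scatter. Compound 4 is estimated at 200 nM, range 70 nM to 600 nM. The expected step is a 1.9-fold higher number from compound 2 to compound 4 (0.28 log units; within the scatter).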

Compound 4, concentration for 50% growth inhibition: 120 nM
Compound 4: middle estimate off by 1.7-fold (0.22 log units), on the high side; the measured number falls inside the stated range.
By their numbers in this assay, from the lowest: compounds 2 and 4 (each within the scatter of the next); then compound 1; then compound 3.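

In this assay, amino in place of dimethylamino at the end of the chain makes no difference beyond the scatter: a 1.1-fold higher number from compound 2 to compound 4 (0.06 log units; within the scatter). So the end group's two methyl groups are not needed, while the chain itself still counts, with a 23-fold lower number from compound 3 to compound 4 (1.36 log units; beyond the scatter), and the guanidine-ended chain is also left behind, with a 3.3-fold lower number from compound 1 to compound 4 (0.51 log units; beyond the scatter). No measurement at hand explains why the amine's substitution leaves the number in place.

Still open, as far as these compounds go, is how a longer chain, or a carboxylic acid in place of amino at the chain end, would read in this assay.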